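Replacing the carbonyl-bearing link of compound 2

The source may report more compounds than this note shows. Statements on the series, on what has been measured and on what is new or still open speak of the compounds shown alone.

Two compounds share a core: compound 1, `CC(C)c1onc(-c2c(Cl)cccc2Cl)c1COc1ccc(N(C)C(=O)c2ccc(C(=O)O)cc2)c(C(F)(F)F)n1`, and compound 2, `CC(C)c1onc(-c2c(Cl)cccc2Cl)c1COc1ccc(NC(=O)c2ccc(C(=O)O)cc2)c(C(F)(F)F)n1`. In a functional assay on HEK293 cells for agonist activity at Bile acid receptor (Homo sapiens), read by a luciferase reporter (on this read-out higher numbers stand for an effect only at larger amounts of compound and lower numbers for an effect already at smaller amounts), compound 1 gives 208 nM, and compound 2 gives 385 nM. Going by the values given here, the single step between them, a 1.9-fold higher number from compound 1 to compound 2 (0.27 log units; within the scatter), is hydrogen in place of methyl on an amide-type nitrogen. Compound 2 therefore has the higher of the two numbers, a gap that lies within the scatter.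

Compound 3, `CC(C)c1onc(-c2c(Cl)cccc2Cl)c1COc1ccc(NCc2ccc(C(=O)O)cc2)c(C(F)(F)F)n1`, is not yet measured. It differs from compound 2 by 4-carboxybenzyl in place of (4-carboxyphenyl)carbonyl on a nitrogen on an aromatic ring. Among the compounds with values here, no measured step touches this part of the molecule: the only known step concerns the methyl on that nitrogen and was within the scatter, so it says little about exchanging the group attached to the nitrogen. Without precedent, a modest weakening is assumed, and compound 3 is expected at 1000 nM, between 300 nM and 4000 nM. This corresponds to an estimated step of a 2.6-fold higher number from compound 2 to compound 3 (0.41 log units; beyond the scatter).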

Compound 3, half-maximal effective concentration: 101 nM
Beside the measured number, compound 3's estimate is 9.9-fold (1.00 log units) above it, outside the stated range (below it).
By their numbers in this assay, from the lowest: compound 3; then compounds 1 and 2 (each within the scatter of the next).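

In this assay, swapping the carbonyl-bearing link for a plain benzyl link gives a 3.8-fold lower number from compound 2 to compound 3 (0.58 log units; beyond the scatter), so the compound acts at smaller amounts. The earlier pair changed only the group on the nitrogen and stayed within the scatter, whereas this is the first change shown to shift the number beyond it, which makes the link itself a place where the structure matters and shows that the carbonyl is not required for agonist activity here. No measurement is available that explains why removing the carbonyl has this effect.

Going by these compounds, it remains open whether a methyl on the nitrogen of compound 3 would matter as little as it does between compound 1 and compound 2. On these data alone, how a sulfonyl link or a longer chain would compare at this position is also open.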